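Chloro to phenyl on a shared core

The source may hold more compounds than are shown below. What is called first, only, known or untested is meant among the compounds shown, and "the series" means these compounds.

Measured so far in an ADME assay on BJ cells (Homo sapiens) for cytotoxicity, with a stated time of 72 h; a higher number here means that more compound is needed for the effect, a lower number that less compound is needed:
Compound 1 `COCCOc1cc2ncnc(-n3nc(-c4ccccn4)nc3N)c2cc1OCCOC`: > 27000 nM (a limit)
Compound 2 `COc1cc2nc(Cl)nc(-n3nc(-c4ccccn4)nc3N)c2cc1OC`: > 13000 nM (a limit)

Neither reading is a number. Going by these compounds, compound 2 stands at > 13000 nM, which is a limit of this assay, and its true position is unknown. Compound 1 also gives only a limit, > 27000 nM. Among the measured compounds shown here, no measured step between compounds that differ in one place is available as a guide.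

Compound 3 `COc1cc2nc(-c3ccccc3)nc(-n3nc(-c4ccccn4)nc3N)c2cc1OC` has phenyl in place of chloro on an aromatic carbon, between two ring nitrogen atoms: phenyl in place of chloro on an aromatic carbon. With so little to go on, only a modest move in this assay toward less compound needed is expected, and the reading may again be only a limit. The expected step is an at least 1.0-fold lower number from compound 2 to compound 3 (0.03 log units; that floor lies within the scatter). For compound 3 the estimated value is 12000 nM, with an expected range of 3000 nM to 30000 nM.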

Compound 3, half-maximal effective concentration: > 27000 nM
Compound 3 was reported as a limit; the forecaster's own chance of this, stated with the estimate: 50%; middle value at least 2.2-fold (0.35 log units) away from the limit.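

In this assay compound 3 gives > 27000 nM, which is a limit. Compound 2 gives > 13000 nM, also a limit, so no step can be read between compound 2 and compound 3. The compounds shown leave open whether phenyl in place of chloro changes the reading at all.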